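One Chloro Group Removed, Read Across Two Cores

A few compounds are considered here, and "the series" means these few. Any claim that something is new, unique, unknown or untested is made for them only; others in the source may bear on it.

Three compounds were tested in a functional assay on A549 cells (Homo sapiens) for inhibition, read by MTT assay, with a stated time of 72 h; on this read-out higher numbers stand for weaker inhibition and lower numbers for stronger inhibition. Compound 1 `C=C(c1ccc(Cl)c(Cl)c1)C1COC(C)(C)OO1` gives > 100000 nM, which is a limit of the assay rather than a number. Compound 2 `C=C(c1ccc(Cl)c(Cl)c1Cl)C1COC(C)(C)OO1` gives 52100 nM in this assay. These two share a core and differ by hydrogen in place of chloro on an aromatic carbon; the step of an at least 1.9-fold higher number from compound 2 to compound 1 (0.28 log units; that floor lies within the scatter) weakens inhibition, though its floor lies within the usual scatter. Compound 3 `C=C(c1ccc(Cl)c(Cl)c1Cl)C1COC2(CCCCC2)OO1` has a core that differs from that of compound 2 in a way not broken down here; in this assay compound 3 gives 1370 nM, the lowest number of the set, and its gap to compound 2 lies beyond the scatter.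

Compound 4 `C=C(c1ccc(Cl)cc1Cl)C1COC2(CCCCC2)OO1` has not been measured. It differs from compound 3 by hydrogen in place of chloro on an aromatic carbon. This is the same kind of change as from compound 2 to compound 1, not the same: there the hydrogen entered ortho to a chloro group, ortho to a large group and meta to a chloro group, whereas here it enters ortho to two chloro groups and meta to a large group. Resting on an at least 1.9-fold higher number from compound 2 to compound 1 (0.28 log units; that floor lies within the scatter), compound 4 is expected to show a somewhat higher number, a step of a 2.3-fold higher number from compound 3 to compound 4 (0.37 log units; beyond the scatter). Compound 4 is therefore estimated at 3200 nM, within a range from 1000 nM to 12000 nM.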

Compound 4, half-maximal inhibitory concentration: 810 nM
Compound 4: the middle estimate sits 4.0-fold (0.60 log units) above what was measured; the measured number lies below the stated range.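

In this assay, the new step is a 1.7-fold lower number from compound 3 to compound 4 (0.23 log units; within the scatter), so on this core hydrogen in place of chloro on an aromatic carbon gives no change that can be read. Set beside the earlier step, the same change does not carry over in equal size from one core to the other: the same change on two cores in this assay, an at least 1.9-fold higher number (0.28 log units; that floor lies within the scatter) from compound 2 to compound 1 and a 1.7-fold lower number (0.23 log units; within the scatter) from compound 3 to compound 4, at least 3.2-fold (0.51 log units) apart, beyond the scatter of two such steps This does not separate the core from the place of the change, the hydrogen here entering ortho to two chloro groups and meta to a large group, and the earlier step rests on a limit of the assay: the limit of > 100000 nM in this assay, at which 1 of the 4 values shown sits.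

The compounds shown leave open whether the change would read the same way on any further core, and whether a methoxy group, a nitrile or an amine in place of the chloro group would follow either step. They also leave open how large the earlier step really is, as compound 1 has no number to set against compound 2.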